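Adding a Methyl: Expected Metabolic Stability of Compound 4

The source may report more compounds than this note shows. Statements on the series, on what has been measured and on what is new or still open speak of the compounds shown alone.

Compound 1 `O=C(OCc1ccccc1)c1coc(-c2ccccc2)n1`: 2.7%
Compound 2 `CCC(C)c1ccccc1OC(=O)c1coc(-c2ccccc2)n1`: 8.3%
Compound 3 `CCCc1ccccc1OC(=O)c1coc(-c2ccccc2)n1`: 5.4%

All three were tested in an ADME assay on microsomes from liver (Rattus norvegicus, strain Sprague-Dawley) for metabolic stability, read by LC-MS, with a stated time of 15 min, tested at 20 uM; a lower number here means that less of the compound is left, a higher number that more of the compound is left. Compound 1 gives the lowest of the three numbers, but its gaps to compound 3 and to compound 2 both lie within the scatter, so no order can be read from them. Compound 3 and compound 2 differ in one place: methyl in place of hydrogen on a saturated chain carbon bound to an aromatic carbon and a saturated chain carbon. That change made a step of a number 2.9 percentage points higher from compound 3 to compound 2 (within the scatter), again within the scatter. Compound 1 and compound 3 differ in more than one place; the difference between the two cores is not broken down here.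

Compound 4 `C[C@H](OC(=O)c1coc(-c2ccccc2)n1)c1ccccc1` has not been measured. It differs from compound 1 by methyl in place of hydrogen on a saturated chain carbon bound to an aromatic carbon and an oxygen next to a carbonyl group. This is the same kind of change as from compound 3 to compound 2, though the place differs: there the carbon was bound to an aromatic carbon and a saturated chain carbon, here to an aromatic carbon and an oxygen next to a carbonyl group. Resting on compound 3 and the step of a number 2.9 percentage points higher from compound 3 to compound 2 (within the scatter), the step from compound 1 to compound 4 is expected to be small, about a number 2.3 percentage points higher from compound 1 to compound 4 (within the scatter). Compound 4 is therefore estimated at 5%, between 0% and 15%.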

Compound 4, percent of the compound remaining: 5%
The estimate for compound 4 equals the measured number at the digits printed, and the stated range covers the measured number.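

In this assay, putting the methyl on the core of compound 1 gave a step of a number 2.3 percentage points higher from compound 1 to compound 4 (within the scatter). Set beside the earlier case, the same change looks alike on the two cores: the same change on two cores in this assay, a number 2.9 percentage points higher (within the scatter) from compound 3 to compound 2 and a number 2.3 percentage points higher (within the scatter) from compound 1 to compound 4, 0.6 percentage points apart, within the scatter of two such steps This shows only that the methyl made no readable difference on either core; it does not show that the methyl has no effect at all, since steps this small cannot separate a slight real effect from none, and two pairs, with the methyl on differently bound carbons, make no rule for other cores.

The compounds shown leave open whether a larger group on the same saturated chain carbon, such as an ethyl or a cyclopropyl, or an amine there, would move the number beyond the scatter. They also leave open what an amide in place of the ester would do on this core.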